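Methoxy in Place of Fluoro: Estimating Compound 4

The source may hold more compounds than are shown below. What is called first, only, known or untested is meant among the compounds shown, and "the series" means these compounds.

Compound 2 `COc1cc(-n2ncnc2-c2ccc(F)cc2)cc(OC)c1OC` is one of three compounds tested in a functional assay on Jurkat cells (Homo sapiens) for antiproliferative activity, read by MTT assay, with a stated time of 72 h; on this read-out higher numbers stand for weaker inhibition and lower numbers for stronger inhibition. In this assay compound 2 reaches only the limit of > 10000 nM. Compound 1 `COc1cc(-c2ncnn2-c2cccc(N)c2)cc(OC)c1OC` likewise gives only the limit of > 10000 nM. Compound 3 `COc1cc(-c2ncnn2-c2ccc(Cl)c(Cl)c2)cc(OC)c1OC` also stops at the limit of > 10000 nM. For the measured compounds named here, the single step between measured compounds, a step that the two limits leave unreadable from compound 1 to compound 3, cannot be sized, since both of its ends sit at the limit of > 10000 nM in this assay, at which 3 of the 3 values shown sit. Compound 4 `COc1ccc(-c2ncnn2-c2cc(OC)c(OC)c(OC)c2)cc1` differs from compound 2 by methoxy in place of fluoro on an aromatic carbon. Going by the values given here, no measured step bears directly on this change, and the values shown offer no direction for it. Compound 4 is therefore expected to sit near the limit as well, the step of a number no higher from compound 2 to compound 4 (the limit leaves the size open) being an estimate with no support for a change beyond the scatter. The estimate for compound 4 is 10000 nM, ranging from 2000 nM to 50000 nM.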

Compound 4, half-maximal inhibitory concentration: 50 nM
Compound 4: middle estimate off by 200-fold (2.30 log units), on the high side; measured number outside the range, below it.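

In this assay, replacing 4-fluorophenyl with 4-methoxyphenyl gives an at least 200-fold lower number from compound 2 to compound 4 (2.30 log units; beyond the scatter), so a single change on this aromatic carbon, para to a large group, is enough to bring a measurable number. Compound 4 is the only compound shown that leaves the limit: the limit of > 10000 nM in this assay, at which 3 of the 4 values shown sit. Compound 2 gives > 10000 nM, which is a limit, so the step has no upper size. From the compounds shown here alone, whether an ethoxy group, a hydroxyl group or an amine on this carbon would also leave the limit stays open. So does whether methoxy alone suffices here, since only this one pair tests the change.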